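Three Limit Values and an Untested Benzyl Analogue

A few compounds are considered here, and "the series" means these few. Any claim that something is new, unique, unknown or untested is made for them only; others in the source may bear on it.

Compound 1, `O=C(c1ccc(F)cc1)c1ccn(-c2ccc3c(c2)B(O)OC3)c1`, in an ADME assay on L929 cells (Mus musculus) for cytotoxicity, read by resazurin assay, with a stated time of 72 h (a lower number here means a stronger inhibitor, a higher number a weaker inhibitor), gives > 10 ug/mL, which is a limit of the assay and not a number.
Compound 2, `COc1ccc(C(=O)c2ccn(-c3ccc4c(c3)B(O)OC4)c2)cc1`, gives > 10 ug/mL, again a limit.
Compound 3, `CCCC(=O)c1ccn(-c2ccc3c(c2)B(O)OC3)c1`, gives > 10 ug/mL, also a limit.

All three measured compounds therefore sit at the same point, (the limit of > 10 ug/mL in this assay, at which 3 of the 3 values shown sit), and none of them yields a number. Compound 3 stands nowhere below or above the others that can be read; it simply shares the limit. The steps among the measured compounds are likewise unreadable: a step that the two limits leave unreadable from compound 1 to compound 2, a step that the two limits leave unreadable from compound 1 to compound 3 and a step that the two limits leave unreadable from compound 2 to compound 3, because each end of each pair is only a limit.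

Compound 4, `OB1OCc2ccc(-n3ccc(Cc4ccccc4)c3)cc21`, differs from compound 3 by benzyl in place of propylcarbonyl on an aromatic carbon. Within the data shown here, the only steps that bear on this change are the two in which the group on the carbonyl carbon was swapped, from compound 1 to compound 3 and from compound 2 to compound 3, and both were left unreadable by the limits. Among the measured compounds shown here, no measured step shows any change in this assay, so no step beyond the scatter is expected from compound 3 to compound 4, which is written as a step that the limit leaves unreadable from compound 3 to compound 4.

Compound 4 is therefore expected to come out at about 15 ug/mL, most likely reported again as a limit, with a range from 5 ug/mL to 40 ug/mL.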

Compound 4, half-maximal inhibitory concentration: > 10 ug/mL
Compound 4: only a limit was reported; the forecaster's own chance of this, stated with the estimate: 75%; the middle value is on the limit's open side.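

Compound 4, like compound 3, returns only a limit, so no step can be read between them. All the compounds shown stand at one point: the limit of > 10 ug/mL in this assay, at which 4 of the 4 values shown sit.

What they leave open is where any of them truly lies beyond that limit in this assay, and whether exchanging propylcarbonyl for benzyl changes the read-out at all.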